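The source may hold more compounds than are shown below. What is called first, only, known or untested is meant among the compounds shown, and "the series" means these compounds.

The measured compounds in a functional assay on A549 cells (Homo sapiens) for inhibition, read by MTT assay, with a stated time of 72 h; on this read-out higher numbers stand for weaker inhibition and lower numbers for stronger inhibition:

Compound 1, `CN(C(=O)NC(=O)c1ccccc1F)c1nc(C(F)(F)F)c(C(=O)N/N=C/c2ccccc2C(F)(F)F)s1`, gives 6.32 ug/mL.
Compound 2, `CNc1nc(C(F)(F)F)c(C(=O)N/N=C/c2ccccc2C(F)(F)F)s1`, reaches only the limit of the measurement, > 100 ug/mL.
Compound 3, `CN(C(=O)NC(=O)c1ccccc1F)c1nc(C(F)(F)F)c(C(=O)N/N=C/c2ccc(C(F)(F)F)cc2)s1`, gives 5.68 ug/mL.

Compounds 1 and 3 share a core and differ only in the aryl group attached to the hydrazone carbon: 4-(trifluoromethyl)phenyl in place of 2-(trifluoromethyl)phenyl on a carbon with a double bond to nitrogen. This rearrangement changes little, the step being a 1.1-fold lower number from compound 1 to compound 3 (0.05 log units; within the scatter), so the two values cannot be ordered against each other.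

The other change is far more consequential. Compound 2 differs from compound 1 in that (hydrogen in place of ((2-fluorophenyl)carbonyl)carbamoyl on a nitrogen on an aromatic ring). This produces an at least 15-fold higher number from compound 1 to compound 2 (1.19 log units; beyond the scatter), and the value of compound 2 is a limit, as recorded by the limit of > 100 ug/mL in this assay, at which 1 of the 3 values shown sits, so the true loss may be even larger than the stated figure.

Compound 4, `CNc1nc(C(F)(F)F)c(C(=O)N/N=C/c2ccc(C(F)(F)F)cc2)s1`, has not yet been measured in this assay. Relative to compound 3 it carries exactly the same change: hydrogen in place of ((2-fluorophenyl)carbonyl)carbamoyl on a nitrogen on an aromatic ring. The surroundings of the altered nitrogen are described in identical terms for both pairs, so this is the same change, not merely the same kind.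

Given that removing this group from compound 1 gave an at least 15-fold higher number from compound 1 to compound 2 (1.19 log units; beyond the scatter), compound 4 is expected to show a step of similar size, a 26-fold higher number from compound 3 to compound 4 (1.42 log units; beyond the scatter), from compound 3. Compound 4 is therefore estimated at 150 ug/mL, within a range of 40 ug/mL to 600 ug/mL, and it is likely that the assay again reports only a limit rather than a number.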

Compound 4, half-maximal inhibitory concentration: > 100 ug/mL
Compound 4: a limit, no number; the forecaster's own chance of this, stated with the estimate: 80%; the middle value does not contradict the limit.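

In this assay compound 4 gives > 100 ug/mL, which is a limit of the assay and not a number, so its true value remains unknown: the limit of > 100 ug/mL in this assay, at which 2 of the 4 values shown sit.

Replacing ((2-fluorophenyl)carbonyl)carbamoyl with hydrogen on the nitrogen gives an at least 17-fold higher number from compound 3 to compound 4 (1.24 log units; beyond the scatter), so the large loss seen on the core of compound 1 recurs on a second core, the one carrying 4-(trifluoromethyl)phenyl. This shows that the change carries over between these two cores in the same direction and is large on both, but it does not show that the size of the step is the same on each: the same change on two cores in this assay, an at least 15-fold higher number (1.19 log units; beyond the scatter) from compound 1 to compound 2 and an at least 17-fold higher number (1.24 log units; beyond the scatter) from compound 3 to compound 4; the limit leaves it open whether they differ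

The compounds shown leave open which part of the departing group matters, since the nitrogen carries either the whole group or hydrogen, and nothing here tells whether a plain carbamoyl, an acetyl or a benzoyl without the fluorine would stand nearer compound 3 or compound 4. Also open, going by these compounds, is whether the step would hold on cores with a chlorine or a methoxy group on the phenyl ring in place of trifluoromethyl.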